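Swapping the pyrazolyl for benzamido on the shared core

The source may report more compounds than this note shows. Statements on the series, on what has been measured and on what is new or still open speak of the compounds shown alone.

Measured so far:
compound 1 `CN(C)c1ccc2oc(-c3cc(-c4cnn(C5CCNCC5)c4)cnc3N)nc2c1` 1760 nM
compound 2 `Nc1ncc(-c2cnn(C3CCNCC3)c2)cc1-c1nc2ccc(Nc3cc(C(F)(F)F)cc(C(F)(F)F)c3)cc2o1` 4200 nM
compound 3 `Nc1ncc(-c2cnn(C3CCNCC3)c2)cc1-c1nc2ccc(-c3cn[nH]c3)cc2o1` 1780 nM

All three compounds were tested in an assay on isolated protein for inhibition of G protein-coupled receptor kinase 5 (Homo sapiens), read by TR-FRET, with stated times of 10 min and 1 h; on this read-out higher numbers stand for weaker inhibition and lower numbers for stronger inhibition. Compound 3 gives 1780 nM, the second highest of the three numbers; compound 1 gives 1760 nM, a difference within the scatter, whereas compound 2 gives 4200 nM, a gap beyond the scatter. Compound 4 `Nc1ncc(-c2cnn(C3CCNCC3)c2)cc1-c1nc2ccc(NC(=O)c3ccccc3)cc2o1` has not been measured. It differs from compound 3 in one place: benzamido in place of 1H-pyrazol-4-yl on an aromatic carbon. For the measured compounds named here, no step between measured compounds matches this change, so the expectation rests only on the spread seen here. A step from compound 3 to compound 4 of about a 1.4-fold higher number from compound 3 to compound 4 (0.15 log units; within the scatter) is expected, toward weaker inhibition but possibly not beyond the scatter. Compound 4 is estimated at 2500 nM, ranging from 900 nM to 7000 nM.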

Compound 4, half-maximal inhibitory concentration: 3490 nM
Compound 4: the middle estimate sits 1.4-fold (0.14 log units) below what was measured; the range from low to high includes it.
By their numbers in this assay, from the lowest: compounds 1, 3, 4 and 2 (each within the scatter of the next, the first and the last beyond it).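

Benzamido in place of 1H-pyrazol-4-yl gives a 2.0-fold higher number from compound 3 to compound 4 (0.29 log units; within the scatter) on this aromatic carbon of the shared core. This position therefore accepts a larger group, with a carbon-only six-membered ring and a carbonyl, without a change beyond the scatter. Nothing measured here accounts for the size of this step.

As far as these compounds go, whether a simple amine or a carboxylic acid at this position would shift the number beyond the scatter remains open. So does the effect of a longer chain in place of the benzamido phenyl ring.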